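Swapping a halogenated phenyl on a shared core

The source may report more compounds than this note shows. Statements on the series, on what has been measured and on what is new or still open speak of the compounds shown alone.

Of the compounds shown here, three built on a shared core have been tested in a functional assay on RAW264.7 cells (Mus musculus) for inhibition, with a stated time of 4 days; a higher number here means a weaker inhibitor, a lower number a stronger inhibitor. Compound 1 `COc1cc(/C=C/C(=O)c2cccc(-n3cc(-c4cccc(Cl)c4)nn3)c2)ccc1O` gives 14300 nM in this assay. Compound 2 `COc1cc(/C=C/C(=O)c2cccc(-n3cc(-c4ccc(Br)cc4)nn3)c2)ccc1O` differs from compound 1 by a single change, (4-bromophenyl in place of 3-chlorophenyl on an aromatic carbon). In this assay compound 2 gives 19100 nM. That step is a 1.3-fold higher number from compound 1 to compound 2 (0.13 log units; within the scatter). Compound 3 `COc1ccc(/C=C/C(=O)c2cccc(-n3cc(-c4cccc(Cl)c4)nn3)c2)cc1O` is built from the same atoms as compound 1, joined differently, with the difference being (3-hydroxy-4-methoxyphenyl in place of 4-hydroxy-3-methoxyphenyl on a double-bonded chain carbon bound to a double-bonded chain carbon). In this assay compound 3 gives 6610 nM. The step here is a 2.2-fold lower number from compound 1 to compound 3 (0.34 log units; beyond the scatter). Compound 3 carries the lowest number of the three, and its steps to compound 1 and to compound 2 are both beyond the scatter, so among these three it is the strongest inhibitor.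

Compound 4 `COc1ccc(/C=C/C(=O)c2cccc(-n3cc(-c4ccc(Br)cc4)nn3)c2)cc1O` has not yet been measured. It stands to compound 3 as compound 2 stands to compound 1: the difference is 4-bromophenyl in place of 3-chlorophenyl on an aromatic carbon, the same change made at the same place as before. The one earlier occasion on which this change was made gave a 1.3-fold higher number from compound 1 to compound 2 (0.13 log units; within the scatter), a step within the scatter. Resting on that single example and on compound 3 giving 6610 nM, the step from compound 3 to compound 4 in this assay is expected to be a 1.3-fold higher number from compound 3 to compound 4 (0.11 log units; within the scatter). Compound 4 is therefore estimated at 8600 nM, with a likely range from 4500 nM to 17000 nM. Whether the measurement bears this out remains to be seen.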

Compound 4, half-maximal inhibitory concentration: 6570 nM
Compound 4: middle estimate off by 1.3-fold (0.12 log units), on the high side; the measured number falls inside the stated range.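

In this assay, putting 4-bromophenyl in place of 3-chlorophenyl gives a 1.0-fold lower number from compound 3 to compound 4 (0.00 log units; within the scatter), so on neither core does this swap move the number beyond the scatter, and the two cores agree: the same change on two cores in this assay, a 1.3-fold higher number (0.13 log units; within the scatter) from compound 1 to compound 2 and a 1.0-fold lower number (0.00 log units; within the scatter) from compound 3 to compound 4, 1.3-fold (0.13 log units) apart, within the scatter of two such steps. The other change, 3-hydroxy-4-methoxyphenyl in place of 4-hydroxy-3-methoxyphenyl, gives a 2.9-fold lower number from compound 2 to compound 4 (0.46 log units; beyond the scatter), a step in the same direction as before and of a size that cannot be told apart from the earlier one: the same change on two cores in this assay, a 2.2-fold lower number (0.34 log units; beyond the scatter) from compound 1 to compound 3 and a 2.9-fold lower number (0.46 log units; beyond the scatter) from compound 2 to compound 4, 1.3-fold (0.13 log units) apart, within the scatter of two such steps. Within these four compounds, then, each change carries from one core to the other, but this rests on only two pairs per change in a single assay, and it does not show that either change would behave the same way on any other core, or why either has the effect it does.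

The compounds shown leave open whether the picture would hold if the halogenated phenyl gave way to an unsubstituted phenyl, or to a phenyl bearing an amine or a carboxylic acid. They also leave open what would happen to the number if the hydroxy group on the other phenyl were replaced by a second methoxy group.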